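A Methyl Added to the Fused Ring of Compound 1

The source may hold more compounds than are shown below. What is called first, only, known or untested is meant among the compounds shown, and "the series" means these compounds.

Compound 1 `CCO/N=C1\C(=O)N(CCCN2CCN(c3cc4c(cc3F)c(=O)c(C(=O)O)cn4C3CC3)CC2)c2ccccc21` and compound 2 `O=C1C(=O)N(CCCN2CCN(c3cc4c(cc3F)c(=O)c(C(=O)O)cn4C3CC3)CC2)c2ccccc21` share the same core and were both examined in an ADME assay on Vero cells (Chlorocebus sabaeus) for cytotoxicity, read by MTT assay, with a stated time of 72 h; on this read-out higher numbers stand for lower toxicity in this test and lower numbers for higher toxicity in this test. In this assay compound 1 gives 64 ug/mL, and compound 2 gives 128 ug/mL. Compound 1 holds the lower of the two numbers, yet the gap to compound 2 lies within the scatter of repeated runs, so the two readings cannot be separated. Among the compounds with values here, no two measured compounds differ in a single place, so no measured step bears on what follows.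

Compound 3 `CCO/N=C1\C(=O)N(CCCN2CCN(c3cc4c(cc3F)c(=O)c(C(=O)O)cn4C3CC3)CC2)c2ccc(C)cc21` is the unmeasured analogue of compound 1. The difference between them is methyl in place of hydrogen on an aromatic carbon. Within the data shown here, nothing among the measured compounds speaks to this particular change. The estimated step is no change at the digits printed from compound 1 to compound 3 (within the scatter), and it is expected to be small, with no direction beyond the scatter in this assay. For compound 3 in this assay the expected value is 64 ug/mL, with a range from 32 ug/mL to 128 ug/mL.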

Compound 3, half-maximal cytotoxic concentration: 128 ug/mL
For compound 3 the middle estimate is 2.0-fold (0.30 log units) below the measured one, and the stated range covers the measured number.
By their numbers in this assay, from the lowest: compounds 1, 2 and 3 (each within the scatter of the next).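

In this assay this position now has its first reading: methyl in place of hydrogen on an aromatic carbon, meta to a fused ring and para to a fused ring, gives a 2.0-fold higher number from compound 1 to compound 3 (0.30 log units; within the scatter). The earlier compounds shown here offered no step at this aromatic carbon, and this pair shows that, on the core of compound 1, the added methyl leaves a reading that cannot be told apart from that of the parent, so a single carbon can stand here without a change beyond the scatter in this test. No measurement at hand accounts for the reading of compound 3, so the step stands as an observation without an explanation.

The compounds shown leave open whether a longer chain, a methoxy group, a chlorine atom or an amine on the same aromatic carbon would also stay within the scatter of compound 1. They also leave open whether methyl on this carbon would behave in the same way on the core of compound 2, which carries a carbonyl where compound 1 carries its ethyl oxime ether.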